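Swapping a halogen on a triazole-linked aryl ring

This account rests on a few compounds, and the source may have more. Where it says the series, first, only, none or still open, it means among the compounds named here.

Compound 1 `C=C1C(=O)[C@]23C[C@@]1(O)CC[C@H]2c1ccc(OS(=O)(=O)c2ccc(C)cc2)c(C)c1[C@@H]3Cn1cc(-c2ccc(C)cc2)nn1` and compound 2 `C=C1C(=O)[C@]23C[C@@]1(O)CC[C@H]2c1ccc(OS(=O)(=O)c2ccc(C)cc2)c(C)c1[C@@H]3Cn1cc(-c2ccc(F)cc2)nn1` share one core and differ only in the group on the outer aryl ring. In a functional assay on SMMC-7721 cells (Homo sapiens) for cytotoxicity, read by MTT assay, with a stated time of 4 days (on this read-out higher numbers stand for weaker inhibition and lower numbers for stronger inhibition), compound 1 gives 4410 nM, while compound 2 gives 4280 nM. Going by the values given here, the only measured step, a 1.0-fold lower number from compound 1 to compound 2 (0.01 log units; within the scatter), shows that exchanging methyl for fluoro made no difference beyond the scatter. Compound 2 therefore stands at the lower of the two numbers, but within the scatter of compound 1, so no ranking can be claimed.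

Compound 3 `C=C1C(=O)[C@]23C[C@@]1(O)CC[C@H]2c1ccc(OS(=O)(=O)c2ccc(C)cc2)c(C)c1[C@@H]3Cn1cc(-c2ccc(Br)cc2)nn1` carries the change (bromo in place of fluoro on an aromatic carbon). Among the compounds with values here, the one step available suggests this outer position tolerates small changes without affecting potency, and bromo is another single-atom substituent at the same place. The expected step is a 1.1-fold lower number from compound 2 to compound 3 (0.03 log units; within the scatter), within the scatter. Compound 3 is estimated at 4000 nM, with a range from 2000 nM to 8500 nM.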

Compound 3, half-maximal inhibitory concentration: 4320 nM
Compound 3: middle estimate off by 1.1-fold (0.03 log units), on the low side, and the stated range covers the measured number.
By their numbers in this assay, from the lowest: compounds 2, 3 and 1 (each within the scatter of the next).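

In this assay, going by these compounds alone, bromo in place of fluoro gives a 1.0-fold higher number from compound 2 to compound 3 (0.00 log units; within the scatter) and bromo in place of methyl gives a 1.0-fold lower number from compound 1 to compound 3 (0.01 log units; within the scatter) so the single step seen before now has two more beside it. Methyl, fluoro and bromo at this place on the outer phenyl ring all lie within the scatter of one another, so this read-out does not separate the three groups, a statement that holds for these three compounds only. No measured evidence is available to explain why the three numbers lie so close together.

The compounds shown leave open whether this place would stay as undemanding with quite different groups, such as an amine, a carboxylic acid or a longer chain like butyl. They also leave open whether changes elsewhere on the shared core would matter more.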